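Shortening the amine-bearing chain on a shared core

The source may report more compounds than this note shows. Statements on the series, on what has been measured and on what is new or still open speak of the compounds shown alone.

Measured compounds:
- compound 1 `N[C@H]1CC[C@H](Nc2c(C(=O)NCc3ccco3)nc(Br)c3cccnc23)CC1`: "not determined" (no result reported) in a functional assay on MCF7 cells (Homo sapiens) for cytotoxicity, read by MTT assay, with a stated time of 72 h; on this read-out higher numbers stand for weaker inhibition and lower numbers for stronger inhibition
- compound 2 `NCCCNc1c(C(=O)NCc2ccc(F)cc2)nc(Br)c2cccnc12`: 6000 nM

In this assay, among the measured compounds shown here, compound 2 gives 6000 nM, and this is the only number available here, since compound 1 carries no reported result. Compound 2 therefore stands alone as the reference point for this series.

Compound 3 `NCCNc1c(C(=O)NCc2ccc(F)cc2)nc(Br)c2cccnc12` is the compound still to be measured. It differs from compound 2 in a single place: amino in place of aminomethyl on a saturated chain carbon, two bonds along the chain from a nitrogen on an aromatic ring. Everything else on the shared core, the amide and the bromine, is left untouched.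

For the measured compounds named here, no pair of measured compounds differs in one place, so no step is available to say how such a shortening of the chain has behaved before. In the absence of any such comparison, the expected step is none beyond the usual scatter of this assay, so the step from compound 2 to compound 3 is estimated at no change at the digits printed from compound 2 to compound 3 (within the scatter). Compound 3 is accordingly expected to give about 6000 nM, with a range from 2000 nM to 20000 nM.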

Compound 3, half-maximal inhibitory concentration: 6000 nM
The estimate for compound 3 equals the measured number at the digits printed; low and high end bracket the measured number.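

In this assay, among the compounds shown here, the swap of (3-aminopropyl)amino for (2-aminoethyl)amino gives no change at the digits printed from compound 2 to compound 3 (within the scatter) and is the first step that can be read at this place, a saturated chain carbon two bonds along the chain from a nitrogen on an aromatic ring. On this single pair, the read-out does not separate the two chain lengths, with the amide and the bromine on the shared core left as they were. Nothing measured on these compounds speaks to why the two read the same.

One pair cannot show whether this holds for other chains, so a longer chain such as 4-aminobutyl, or a carboxylic acid in place of the amine, remains an open case. Compound 1 has no reported result, which leaves open how its different amine and amide groups would read on this core.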